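Fluoro for Hydrogen: Compound 1 to Compound 3

A few compounds are considered here, and "the series" means these few. Any claim that something is new, unique, unknown or untested is made for them only; others in the source may bear on it.

Measured so far:
compound 1 `COc1cccc2[nH]cc(C3(c4c[nH]c5cccc(OC)c45)C(=O)Nc4ccccc43)c12` gives 9000 nM in a functional assay on HepG2 cells (Homo sapiens) for cytotoxicity, read by MTT assay, with a stated time of 48 h; on this read-out lower numbers stand for stronger inhibition and higher numbers for weaker inhibition
compound 2 `COc1ccc2[nH]cc(C3(c4c[nH]c5ccc(OC)cc45)C(=O)Nc4ccccc43)c2c1` gives 30200 nM in this assay

Compound 1 holds the lower of the two numbers in this assay; compound 2 stands higher, and the gap between the two lies beyond the scatter. Compound 3 `COc1cccc2[nH]cc(C3(c4c[nH]c5cccc(OC)c45)C(=O)Nc4ccc(F)cc43)c12` differs from compound 1 by fluoro in place of hydrogen on an aromatic carbon. Among the measured compounds shown here, no measured pair shows what such a change does here. The expected step, a 1.2-fold lower number from compound 1 to compound 3 (0.08 log units; within the scatter), is small, not clearly beyond the scatter, and its direction is open. Compound 3 is estimated at 7500 nM, within 2500 nM to 25000 nM.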

Compound 3, half-maximal inhibitory concentration: 18000 nM
Compound 3: the middle estimate sits 2.4-fold (0.38 log units) below what was measured, and the stated range covers the measured number.
By their numbers in this assay, from the lowest: compounds 1, 3 and 2 (each within the scatter of the next, the first and the last beyond it).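

In this assay, among the compounds shown here, the first step between compounds differing in one place reads a 2.0-fold higher number from compound 1 to compound 3 (0.30 log units; within the scatter) for fluoro in place of hydrogen on an aromatic carbon, meta to a fused ring and para to a fused ring. This position thus accepts fluoro without a change that can be told from the scatter. No evidence bears on this result.
Going by these compounds, whether chloro, methoxy or an amine at this position would give a step beyond the scatter stays open, as does the effect of fluoro on the core of compound 2.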